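Swapping a Furan for a Pyridine on a Shared Core

The compounds below may be only part of what the source reports. "The series", "measured", "known", "first", "only" and "open" are said of these compounds alone.

Measured so far:
- compound 1, `Oc1ccc(-c2cc(-c3ccc(Cl)cc3)nc(-c3ccco3)c2)cc1`: 15.8%
- compound 2, `Oc1ccc(-c2cc(-c3ccncc3)nc(-c3ccc(Cl)cc3)c2)cc1`: 5.9%
- compound 3, `Oc1cccc(-c2cc(-c3ccco3)nc(-c3ccccc3Cl)c2)c1`: 0%

All three compounds were tested in an assay on isolated protein for inhibition of DNA topoisomerase 1 (Homo sapiens), with a stated time of 30 min, tested at 100 uM; on this read-out higher numbers stand for a stronger effect at the one concentration tested and lower numbers for a weaker effect. Compound 1 gives 15.8%, and compound 2, which carries the change (pyridin-4-yl in place of furan-2-yl on an aromatic carbon), gives 5.9%. The step of a number 9.9 percentage points lower from compound 1 to compound 2 (within the scatter) is small enough to sit inside the scatter of this kind of measurement, so the two values cannot be told apart with confidence. Compound 3 gives 0%; its gap to compound 1 is beyond the scatter, while its gap to compound 2 is within it. How the core of compound 3 differs from that of compound 1 is not broken down here: the two share the same atoms, joined differently.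

Compound 4, `Oc1cccc(-c2cc(-c3ccncc3)nc(-c3ccccc3Cl)c2)c1`, has not yet been measured in this assay. It arises from compound 3 by the change (pyridin-4-yl in place of furan-2-yl on an aromatic carbon). Within the data shown here, this is the same kind of change as the one from compound 1 to compound 2, but not the same: in compound 3 the exchanged group sits meta to a 2-chlorophenyl group and meta to a 3-hydroxyphenyl group, whereas in compound 1 it sits meta to a 4-chlorophenyl group and meta to a 4-hydroxyphenyl group.

Given that the earlier step of a number 9.9 percentage points lower from compound 1 to compound 2 (within the scatter) stayed within the scatter, the expected step for compound 4 in this assay is about a number 2 percentage points higher from compound 3 to compound 4 (within the scatter), resting on compound 3 starting from 0%. Compound 4 is therefore estimated to give 2%, most likely between 0% and 15%.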

Compound 4, a percentage reported as inhibition, at one concentration (the size of the read-out at that concentration, not a potency): 0%
Compound 4: middle estimate off by 2 percentage points, on the high side; the range from low to high includes it.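

On the core of compound 3, putting pyridin-4-yl in place of furan-2-yl gives, in this assay, no change at the digits printed from compound 3 to compound 4 (within the scatter), so this swap has no readable effect here. Set beside the same swap on the other core, the two steps cannot be told apart: the same change on two cores in this assay, a number 9.9 percentage points lower (within the scatter) from compound 1 to compound 2 and no change at the digits printed (within the scatter) from compound 3 to compound 4, 9.9 percentage points apart, within the scatter of two such steps. This agrees with a swap that carries from one core to the other without a visible effect, but it does not prove that the two cores respond alike, since compound 3 gives only 0%, which leaves little room for a lower number, and a single tested concentration gives no measure of potency.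

The compounds shown hold only furan-2-yl or pyridin-4-yl at this place, so it remains open whether another group there, such as an amine, a carboxylic acid or a longer chain, would raise the number clearly above the scatter. Also open, as far as these compounds go, is what each difference between the two cores contributes on its own, since the 4-hydroxyphenyl and 3-hydroxyphenyl groups and the 4-chlorophenyl and 2-chlorophenyl groups never change one at a time here.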